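Every Neighbour Sits at the Assay Limit

A few compounds are considered here, and "the series" means these few. Any claim that something is new, unique, unknown or untested is made for them only; others in the source may bear on it.

Of the compounds shown here, three sharing one core have been tested in a functional assay on NIH3T3 cells (Mus musculus); a lower number here means that less compound is needed, a higher number that more compound is needed for the effect. Compound 1 `COC(=O)[C@H](CCSC)NC(=O)c1ccc(NCc2cncn2Cc2ccc(C)cc2)cc1-c1ccccc1` reached only the assay limit, giving > 10 uM. Compound 2 `COC(=O)[C@H](CCSC)NC(=O)c1ccc(NCc2cncn2Cc2cccc(C#N)c2)cc1-c1ccccc1` likewise gave the limit > 10 uM. Compound 3 `COC(=O)[C@H](CCSC)NC(=O)c1ccc(NCc2cncn2Cc2ccc(Cl)cc2)cc1-c1ccccc1` stands at the same limit, > 10 uM, which is a limit and not a measured number. Because (the limit of > 10 uM in this assay, at which 3 of the 3 values shown sit), the steps a step that the two limits leave unreadable from compound 1 to compound 2, a step that the two limits leave unreadable from compound 1 to compound 3 and a step that the two limits leave unreadable from compound 2 to compound 3 cannot be sized. Compound 4 `COC(=O)[C@H](CCSC)NC(=O)c1ccc(NCc2cncn2Cc2ccccc2C)cc1-c1ccccc1` differs from compound 3 by 2-methylphenyl in place of 4-chlorophenyl on a saturated chain carbon bound to an aromatic nitrogen. All measured steps run between limits and reveal nothing about the size of such a change. Compound 4 is therefore expected to remain near the limit, with the step that the limit leaves unreadable from compound 3 to compound 4 estimated as small. The estimated value for compound 4 is 15 uM, ranging from 4 uM to 60 uM.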

Compound 4, concentration for half-maximal effect: > 10 uM
Compound 4: a limit, no number; the forecaster's own chance of this, stated with the estimate: 75%; the middle value lies beyond the limit too.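

Compound 4 also sits at a limit rather than a measured number, so its steps from compound 1, compound 2 and compound 3 cannot be read: the limit of > 10 uM in this assay, at which 4 of the 4 values shown sit. The compounds shown leave open how large any of these steps is, and whether any change at this place gives a measurable value.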